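This account rests on a few compounds, and the source may have more. Where it says the series, first, only, none or still open, it means among the compounds named here.

Within the data shown here, compound 2 `CC(C)(C)C(=O)CN1C(=O)N(CC(=O)Nc2cccc(-c3nn[nH]n3)c2)N=C(C2CCCCC2)c2ccccc21` is the only compound here with a numeric result in an assay on CHO-K1 cells for displacement of a labelled ligand from Cholecystokinin receptor type A (Homo sapiens) (a higher number here means a weaker inhibitor, a lower number a stronger inhibitor), where compound 2 gives 1740 nM. Compound 1 `CC(C)(C)C(=O)CN1C(=O)N(CC(=O)Nc2cccc(CCC(=O)O)c2)N=C(C2CCCCC2)c2ccccc21` differs from it only in carrying a 2-carboxyethyl group in place of the 2H-tetrazol-5-yl. For compound 1 the result in this assay is a limit, > 10000 nM. Among the measured compounds shown here, the one measured step, an at least 5.7-fold lower number from compound 1 to compound 2 (0.75 log units; beyond the scatter), shows that exchanging the carboxylic acid chain for the tetrazole brought the number down from the limit to a measured value. Compound 3 `CN(CC(=O)O)c1cccc(NC(=O)CN2N=C(C3CCCCC3)c3ccccc3N(CC(=O)C(C)(C)C)C2=O)c1` reverses the direction of that exchange: (carboxymethyl)(methyl)amino in place of 2H-tetrazol-5-yl on an aromatic carbon. A carboxylic acid on a short chain thus returns, now attached through a methylated nitrogen. Given that the step of an at least 5.7-fold lower number from compound 1 to compound 2 (0.75 log units; beyond the scatter) went against such an acid chain, compound 3 is expected to come out weaker, by an estimated step of a 3.4-fold higher number from compound 2 to compound 3 (0.54 log units; beyond the scatter). Compound 3 is estimated at 6000 nM in this assay, within 2000 nM to 20000 nM, and the result may again be reported only as a limit.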

Compound 3, inhibition constant: 6460 nM
Beside the measured number, compound 3's estimate is 1.1-fold (0.03 log units) below it; measured number inside the range.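

In this assay, the change at this aromatic carbon gives a 3.7-fold higher number from compound 2 to compound 3 (0.57 log units; beyond the scatter), so a second chain ending in a carboxylic acid also gives a higher number than 2H-tetrazol-5-yl, this time with a measured value rather than a limit. The other new step, an at least 1.5-fold lower number from compound 1 to compound 3 (0.18 log units; that floor lies within the scatter), sets no order between (carboxymethyl)(methyl)amino and 2-carboxyethyl. These two chains cannot be ranked, because that comparison rests on a limit: the limit of > 10000 nM in this assay, at which 1 of the 3 values shown sits.

The compounds shown leave open whether the carboxylic acid or the methylated nitrogen accounts for the step from the tetrazole, since the two enter together. Going by these compounds, it also remains open how a carboxylic acid set directly on the aromatic carbon, a simple amine or a longer chain ending in a tetrazole would compare at this position.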